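Changing the aryl group of compound 1: an expected permeability

This account rests on a few compounds, and the source may have more. Where it says the series, first, only, none or still open, it means among the compounds named here.

Measured so far:
compound 1, `Cc1oc(-c2ccccc2Cl)nc1CN1CCC(C(=O)NCCCN2C[C@H](C)C[C@H](C)C2)CC1` — 352 10^-6 cm/s
compound 2, `Cc1ccccc1-c1nc(CN2CCC(C(=O)NCCCN3CCCC(C(C)C)C3)CC2)c(C)o1` — "not determined" (no result reported)

Among the compounds with values here, in a physicochemical assay for permeability, using PAMPA (on this read-out lower numbers stand for lower permeability and higher numbers for higher permeability), compound 1 gives 352 10^-6 cm/s, the only number available here. For compound 2 the entry in this assay is "not determined" (no result reported). Compound 3 `Cc1ccc(-c2nc(CN3CCC(C(=O)NCCCN4C[C@H](C)C[C@H](C)C4)CC3)c(C)o2)cc1C` differs from compound 1 in one place: 3,4-dimethylphenyl in place of 2-chlorophenyl on an aromatic carbon. Within the data shown here, no measured pair differing in one place exists, so there is no comparable step to lean on. Compound 1 already gives 352 10^-6 cm/s in this assay, so compound 3 is expected to land close to it. The step of a 1.1-fold lower number from compound 1 to compound 3 (0.03 log units; within the scatter) is expected to stay within the usual scatter. Compound 3 is estimated at 330 10^-6 cm/s, within 160 10^-6 cm/s to 650 10^-6 cm/s.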

Compound 3, apparent permeability: 219 10^-6 cm/s
Compound 3: the middle estimate sits 1.5-fold (0.18 log units) above what was measured, and the stated range covers the measured number.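

In this assay, 3,4-dimethylphenyl in place of 2-chlorophenyl gives a 1.6-fold lower number from compound 1 to compound 3 (0.21 log units; within the scatter). This single step shows that, at this aromatic carbon of the five-membered ring, these two substituted phenyl groups can be exchanged without the read-out moving beyond the scatter, although the chlorine is gone and two methyl groups have entered. No measurement shown here offers an explanation for this step. Going by these compounds, how a phenyl ring bearing an amine or a carboxylic acid would behave at this position stays open, as does a pyridine ring in place of the phenyl ring.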